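Shifting a methoxy group on the ring of compound 3

The source may report more compounds than this note shows. Statements on the series, on what has been measured and on what is new or still open speak of the compounds shown alone.

Compound 3 `CCC1(CCCCN2CCN(c3ccccc3OC)CC2)C(=O)Nc2ccccc21` carries a 2-methoxyphenyl on an amine nitrogen in a ring. In a functional assay on the whole organism (strain Wistar) with Rattus norvegicus as the target, with a stated time of 5 min (a lower number here means that less compound is needed, a higher number that more compound is needed for the effect), compound 3 gives 10 mg/kg. Compound 1 `CCC1(CCCCN2CCN(c3ccc(F)cc3)CC2)C(=O)Nc2ccccc21`, with a 4-fluorophenyl in that place, gives 10 mg/kg; the two values stand level, and the step of no change at the digits printed from compound 1 to compound 3 (within the scatter) lies within the scatter. Compound 2 `CCC1(CCCCN2CCN(c3ccccc3Cl)CC2)C(=O)Nc2ccccc21`, bearing a 2-chlorophenyl, reaches only a limit of the assay, > 20 mg/kg. From compound 2 the swap of methoxy for chloro, an at least 2.0-fold lower number from compound 2 to compound 3 (0.30 log units; that floor lies within the scatter), is therefore itself only a floor, as is an at least 2.0-fold higher number from compound 1 to compound 2 (0.30 log units; that floor lies within the scatter); the one firm point behind both is the limit of > 20 mg/kg in this assay, at which 1 of the 3 values shown sits.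

Compound 4 `CCC1(CCCCN2CCN(c3cccc(OC)c3)CC2)C(=O)Nc2ccccc21` differs from compound 3 only in where the methoxy sits: 3-methoxyphenyl in place of 2-methoxyphenyl on an amine nitrogen in a ring. Among the compounds with values here, none of the measured steps moves a methoxy from one place to another on this phenyl; the closest comparison is compound 1 to compound 3, where replacing the whole 4-fluorophenyl by 2-methoxyphenyl changed nothing beyond the scatter. On that evidence the step to compound 4 is expected to be no change beyond the scatter, no change at the digits printed from compound 3 to compound 4 (within the scatter). Compound 4 is therefore estimated at 10 mg/kg, with a likely range from 5 mg/kg to 20 mg/kg.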

Compound 4, minimum effective dose: > 20 mg/kg
Compound 4: no number, only a limit; the forecaster's own chance of this, stated with the estimate: 25%; middle value at least 2.0-fold (0.30 log units) from the limit.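

Within the data shown here, until now the methoxy group had been seen only in 2-methoxyphenyl, so its place on this phenyl had not been tested. In this assay, the same atoms joined as 3-methoxyphenyl give an at least 2.0-fold higher number from compound 3 to compound 4 (0.30 log units; that floor lies within the scatter), and the comparison with the 4-fluorophenyl gives an at least 2.0-fold higher number from compound 1 to compound 4 (0.30 log units; that floor lies within the scatter); both are only floors within the scatter, so they hint that the place of the methoxy may matter without showing it. The step between compound 2 and compound 4 cannot be read, as both values are limits, and the firmest point in the set remains the number of compounds that stop at the same limit: the limit of > 20 mg/kg in this assay, at which 2 of the 4 values shown sit.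

From the compounds shown here alone, compound 4 has only a limit, so how far it really lies from compound 3 stays open, and with it whether moving the methoxy has any real effect. Also open, going by these compounds, is how a hydroxy or an ethoxy group would read in place of the methoxy on this phenyl, and whether a plain phenyl would stand level with compound 3 or reach the limit.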